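Working notes: one amine substituent swapped

The source may report more compounds than this note shows. Statements on the series, on what has been measured and on what is new or still open speak of the compounds shown alone.

Values in a functional assay on PC-3 cells (Homo sapiens) for cytotoxicity, read by MTT assay; on this read-out higher numbers stand for weaker inhibition and lower numbers for stronger inhibition:
- compound 1 `Oc1ccc(CN(Cc2ccccc2C(F)(F)F)Cc2ccc(O)c3ncccc23)c2cccnc12`: 179 nM
- compound 2 `Oc1ccc(CN(Cc2cccc(I)c2)Cc2ccc(O)c3ncccc23)c2cccnc12`: 394 nM

For the measured compounds named here, of the two numbers so far in this assay, the higher belongs to compound 2 at 394 nM. Compound 3 `Oc1ccc(CN(Cc2cccs2)Cc2ccc(O)c3ncccc23)c2cccnc12` is the next to be measured, and it differs from compound 2 as follows: thiophen-2-yl in place of 3-iodophenyl on a saturated chain carbon bound to an amine nitrogen. In words, this is thiophen-2-yl in place of 3-iodophenyl on a saturated chain carbon bound to an amine nitrogen. Going by the values given here, only one measured step bears on this place, a 2.2-fold higher number from compound 1 to compound 2 (0.34 log units; beyond the scatter), and it is modest. Among the compounds with values here, no measured compound carries a five-membered ring, so the direction is poorly supported by the data. A step of no more than that modest size is expected, with a slight lean towards a lower number, and it may well stay within the scatter. The expected change is a 1.2-fold lower number from compound 2 to compound 3 (0.09 log units; within the scatter). For compound 3 the estimate is 320 nM, with an expected range of 130 nM to 750 nM.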

Compound 3, half-maximal inhibitory concentration: 44 nM
Estimate against measurement, compound 3: 7.3-fold (0.86 log units) above; the whole stated range lies above it.
By their numbers in this assay, from the lowest: compound 3; then compound 1; then compound 2.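

In this assay this place proves far more responsive than the first pair showed: thiophen-2-yl in place of 3-iodophenyl gives a 9.0-fold lower number from compound 2 to compound 3 (0.95 log units; beyond the scatter) and in place of 2-(trifluoromethyl)phenyl gives a 4.1-fold lower number from compound 1 to compound 3 (0.61 log units; beyond the scatter) as well. For the compounds shown here, the earlier 2.2-fold higher number from compound 1 to compound 2 (0.34 log units; beyond the scatter) compared only two substituted phenyl groups, whereas the five-membered aromatic ring with a sulfur atom now gives the lowest number of the three compounds. Nothing available accounts for this difference.

With a single five-membered ring in the set, the compounds do not separate ring size, the sulfur atom and the absence of a substituent such as iodine or trifluoromethyl on the ring. Furan-2-yl, thiophen-3-yl and unsubstituted phenyl at the same place would bear on that question.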